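This account rests on a few compounds, and the source may have more. Where it says the series, first, only, none or still open, it means among the compounds named here.

Among the compounds with values here, in an ADME assay on microsomes from liver (Rattus norvegicus) for metabolic stability, read by LC-MS, using NADPH, with a stated time of 10 min, tested at 0.1 uM (on this read-out lower numbers stand for slow clearance and higher numbers for fast clearance), compound 1 `CC1SC(c2cccc(C(=O)NCCCCc3ccccc3)c2)N(c2ccc(C3CC3)cc2)C1=O` gives 3130 mL.min-1.g-1 and compound 2 `O=C(NCCCCc1ccccc1)c1cccc(C2SCC(=O)N2c2ccc(C3CC3)cc2)c1` gives 2280 mL.min-1.g-1, so compound 1 stands within the scatter of its only measured neighbour. Compound 3 `COc1ccccc1N1C(=O)C(C)SC1c1cccc(C(=O)NCCCCc2ccccc2)c1` is still unmeasured. Its change from compound 1 is 2-methoxyphenyl in place of 4-cyclopropylphenyl on an amide-type nitrogen in a ring. Within the data shown here, the only measured step, a 1.4-fold lower number from compound 1 to compound 2 (0.14 log units; within the scatter), puts hydrogen in place of methyl on a saturated ring carbon and leaves the amide-type nitrogen untouched. Among the measured compounds shown here, it is therefore no direct guide to this change, and the data hold no step at that place. At most a small move to a lower number is expected in this assay, with nothing beyond the scatter. The expected step is a 1.4-fold lower number from compound 1 to compound 3 (0.13 log units; within the scatter). For compound 3 the estimate is 2300 mL.min-1.g-1, with an expected range from 1000 mL.min-1.g-1 to 4500 mL.min-1.g-1.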

Compound 3, intrinsic clearance in microsomes in the Rattus norvegicus assay: 2910 mL.min-1.g-1
Estimate against measurement, compound 3: 1.3-fold (0.10 log units) below, and the stated range covers the measured number.
By their numbers in the Rattus norvegicus assay, from the lowest: compounds 2, 3 and 1 (each within the scatter of the next).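

Within the data shown here, in the Rattus norvegicus assay, the first change at the amide-type nitrogen in a ring gives a 1.1-fold lower number from compound 1 to compound 3 (0.03 log units; within the scatter), so this position, like the saturated ring carbon before it, has yet to produce a step in clearance beyond the scatter. In a physicochemical assay for solubility, read by turbidimetry, measured as kinetic solubility, at pH 7.4 (on this read-out higher numbers stand for higher solubility and lower numbers for lower solubility), compound 1 gives 2000 nM and compound 3 gives 10000 nM. In the physicochemical assay the same change does register, which separates the two read-outs at this position: the exchange of 4-cyclopropylphenyl for 2-methoxyphenyl goes with higher solubility, with clearance staying within the scatter: the measured solubility of compound 1, 2000 nM, and of compound 3, 10000 nM, a 5.0-fold higher number (0.70 log units; beyond the scatter)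

The compounds shown do not tell whether the solubility step follows from the loss of 4-cyclopropylphenyl or from the entry of 2-methoxyphenyl. Also open, from the compounds shown here alone, is whether any group at this place moves clearance beyond the scatter, for example a phenyl ring bearing a carboxylic acid or a morpholine.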